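A few compounds are considered here, and "the series" means these few. Any claim that something is new, unique, unknown or untested is made for them only; others in the source may bear on it.

In a functional assay on P388 cells (Mus musculus) for cytotoxicity, read by MTT assay, with a stated time of 72 h (on this read-out higher numbers stand for weaker inhibition and lower numbers for stronger inhibition), compound 1 `OCC#CCSc1cnc2ccccc2c1SCC#CCO` gives 5.7 ug/mL and compound 2 `C#CCSc1cnc2ccccc2c1SCC#CCO` gives 4 ug/mL; the step of a 1.4-fold lower number from compound 1 to compound 2 (0.15 log units; within the scatter) is the only one measured so far. Compound 3 `CSc1cnc2ccccc2c1[Se]CC#CCO` gives 2.6 ug/mL and sits at the low end of the three numbers, with compound 1 beyond the scatter above it while the gap to compound 2 stays within the scatter. Compound 4 `CSc1cnc2ccccc2c1SCC#CCO` differs from compound 3 by a group of 6 heavy atoms (4 carbon, 1 oxygen, 1 sulfur; no ring) in place of a group of 6 heavy atoms (4 carbon, 1 oxygen, 1 selenium; no ring), on an aromatic carbon. Among the measured compounds shown here, no measured step exchanges selenium for sulfur, and the step from compound 1 to compound 2 concerns another part of the molecule, so nothing here argues for a change beyond the scatter; the author expects a 1.3-fold higher number from compound 3 to compound 4 (0.13 log units; within the scatter) and estimates 3.5 ug/mL for compound 4, within 1.5 ug/mL to 8 ug/mL.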

Compound 4, concentration for 50% inhibition: 3.1 ug/mL
Compound 4: the middle estimate sits 1.1-fold (0.05 log units) above what was measured, within the range that was stated.
By their numbers in this assay, from the lowest: compounds 3, 4, 2 and 1 (each within the scatter of the next, the first and the last beyond it).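

In this assay, sulfur in place of selenium on the aromatic carbon opposite the ring nitrogen gives a 1.2-fold higher number from compound 3 to compound 4 (0.08 log units; within the scatter), so this exchange produces no change that can be told from the scatter. On the other sulfur-bound chain, hydrogen in place of ethynyl gives a 1.3-fold lower number from compound 2 to compound 4 (0.11 log units; within the scatter), and hydrogen in place of 3-hydroxyprop-1-yn-1-yl gives a 1.8-fold lower number from compound 1 to compound 4 (0.26 log units; within the scatter), so neither replacement can be told from the scatter either. No evidence is available to explain these results. As far as these compounds go, it remains open whether an amine or a carboxylic acid in place of the chain's hydroxyl would shift the number beyond the scatter.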